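Phenoxy in place of benzyl on compound 1

This account rests on a few compounds, and the source may have more. Where it says the series, first, only, none or still open, it means among the compounds named here.

Measured in an ADME assay on cells (Fibroblast, Gallus gallus) for cytotoxicity, read by CCK-8 assay, with a stated time of 48 h; on this read-out higher numbers stand for lower toxicity in this test and lower numbers for higher toxicity in this test:
- compound 1 `CCC(CC)O[C@@H]1C=C(C(=O)O)C[C@H](NCc2ccc(Cc3ccccc3)cc2)[C@H]1NC(C)=O`: > 200000 nM
- compound 2 `CCC(CC)Oc1cccc(CN[C@H]2CC(C(=O)O)=C[C@@H](OC(CC)CC)[C@@H]2NC(C)=O)c1`: > 200000 nM

Compound 1 gives > 200000 nM, which is a limit of the assay and not a number. Compound 2 gives > 200000 nM, which is likewise a limit. The two measured compounds therefore stand together: the limit of > 200000 nM in this assay, at which 2 of the 2 values shown sit. Among the measured compounds shown here, no number is available for either, and no step between measured compounds can be read.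

Compound 3 `CCC(CC)O[C@@H]1C=C(C(=O)O)C[C@H](NCc2ccc(Oc3ccccc3)cc2)[C@H]1NC(C)=O` keeps the core of compound 1 and carries phenoxy in place of benzyl on an aromatic carbon, para to a large group (phenoxy in place of benzyl on an aromatic carbon). For the measured compounds named here, no measured step in this assay speaks to this change, so the expectation rests only on compound 1, whose > 200000 nM is a limit.

The expected size of a number no higher from compound 1 to compound 3 (the limit leaves the size open) is nothing beyond the scatter, with no direction foreseen, and a further limit is the likeliest report. For compound 3 the estimated value is 200000 nM, with an expected range from 100000 nM to 400000 nM.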

Compound 3, half-maximal cytotoxic concentration: > 200000 nM
Compound 3 was reported as a limit (the forecaster's own chance of this, stated with the estimate: 85%); the middle value lies on the limit itself.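

In this assay compound 3 gives > 200000 nM, which is a limit and not a number. Compound 1 also sits at a limit, so no step from compound 1 to compound 3 can be read: the limit of > 200000 nM in this assay, at which 3 of the 3 values shown sit.

The compounds shown leave open how far any of the three lies past that limit, and whether phenoxy and benzyl differ there at all.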